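This account rests on a few compounds, and the source may have more. Where it says the series, first, only, none or still open, it means among the compounds named here.

Measured in an ADME assay on HepG2 2.2.15 cells (Homo sapiens) for cytotoxicity; on this read-out higher numbers stand for lower toxicity in this test and lower numbers for higher toxicity in this test:
- compound 1 `CC(=O)OCCc1c(-c2ccccc2Cl)c2cc(Cl)ccc2[nH]c1=O`: 27000 nM
- compound 2 `CCC(=O)OCCc1c(-c2ccccc2Cl)c2cc(Cl)ccc2[nH]c1=O`: 95000 nM
- compound 3 `O=C(OCCc1c(-c2ccccc2Cl)c2cc(Cl)ccc2[nH]c1=O)c1ccccc1`: 43000 nM

Compound 3, at 43000 nM, lies within the scatter of compound 1 and clearly lower than compound 2. Compound 4 `O=C(CN1C(=O)c2ccccc2C1=O)OCCc1c(-c2ccccc2Cl)c2cc(Cl)ccc2[nH]c1=O` keeps the shared core but changes the group on the carbonyl carbon: a group of 12 heavy atoms (9 carbon, 1 nitrogen, 2 oxygen; one five-membered non-aromatic ring with 1 hetero atom, one six-membered aromatic ring of carbon only) in place of a group of 6 heavy atoms (6 carbon; one six-membered aromatic ring of carbon only), on a carbonyl carbon. Earlier swaps at this carbonyl end gave only limited changes: a 3.5-fold higher number from compound 1 to compound 2 (0.55 log units; beyond the scatter), a 1.6-fold higher number from compound 1 to compound 3 (0.20 log units; within the scatter) and a 2.2-fold lower number from compound 2 to compound 3 (0.34 log units; beyond the scatter). None of these compounds carries a group as large as the incoming one, so the forecast is uncertain. No clear shift in either direction is expected, and the estimated change is a 1.0-fold higher number from compound 3 to compound 4 (0.02 log units; within the scatter). For compound 4 the estimate is 45000 nM, with an expected range of 17000 nM to 115000 nM.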

Compound 4, half-maximal cytotoxic concentration: 960000 nM
Compound 4: middle estimate off by 21-fold (1.33 log units), on the low side; measured number above the stated range.
By their numbers in this assay, from the lowest: compounds 1 and 3 (each within the scatter of the next); then compound 2; then compound 4.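

In this assay the group on a carbonyl carbon can shift the number much further than methyl, ethyl or phenyl had suggested, with compound 4 standing far higher than each of the others (a 22-fold higher number from compound 3 to compound 4 (1.35 log units; beyond the scatter); a 10-fold higher number from compound 2 to compound 4 (1.00 log units; beyond the scatter); a 36-fold higher number from compound 1 to compound 4 (1.55 log units; beyond the scatter)). On this read-out, that means lower toxicity in this test. Nothing available explains the jump.

Still open, as far as these compounds go, is whether the whole incoming group is needed, or whether a plain amine or a carboxylic acid on the saturated chain carbon bound to the carbonyl carbon would give a similar number.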